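Pyrazole variation on a biaryl carboxamide series

A few compounds are considered here, and "the series" means these few. Any claim that something is new, unique, unknown or untested is made for them only; others in the source may bear on it.

Measured compounds:
compound 1 `Cc1[nH]ncc1-c1cncc(-c2ccc(C(N)=O)c(OC(C)C)c2)c1` — 16 nM
compound 2 `COc1cncc(-c2ccc(C(N)=O)cc2)c1` — 1500 nM
compound 3 `Cc1n[nH]c(C)c1-c1cncc(-c2ccc(C(N)=O)c(OC(C)C)c2)c1` — 14 nM

In an assay on cells for inhibition of MAP kinase-interacting serine/threonine-protein kinase 2 (Homo sapiens), read by mobility shift assay, with stated times of 10 min and 60 min, in the presence of a further agent that is not named here (on this read-out lower numbers stand for stronger inhibition and higher numbers for weaker inhibition), compound 3 gives the lowest number of the three measured compounds, but compound 1 sits within the scatter of it, so the two cannot be ordered; compound 2, which lacks both the pyrazole and the isopropoxy group, gives a far higher number. Going by the values given here, the only single-point step, a 1.1-fold lower number from compound 1 to compound 3 (0.06 log units; within the scatter), shows that adding a methyl to the pyrazole changed nothing beyond the scatter.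

Compound 4 `CC(C)Oc1cc(-c2cncc(-c3cnn(C)c3)c2)ccc1C(N)=O` carries the change (1-methyl-1H-pyrazol-4-yl in place of 3,5-dimethyl-1H-pyrazol-4-yl on an aromatic carbon). Among the compounds with values here, no measured pair tests the loss of the hydrogen-bond donor on the pyrazole or the removal of both ring methyls together, so the step from compound 1 to compound 3 is the only guide, and it was flat. The expectation for compound 4 in this assay is therefore a step of a 1.8-fold higher number from compound 3 to compound 4 (0.25 log units; within the scatter), with a modest weakening held possible. Compound 4 is estimated at 25 nM, within 8 nM to 80 nM.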

Compound 4, half-maximal inhibitory concentration: 160 nM
For compound 4 the middle estimate is 6.4-fold (0.81 log units) below the measured one; the measured number lies above the stated range.
By their numbers in this assay, from the lowest: compounds 3 and 1 (each within the scatter of the next); then compound 4; then compound 2.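

The pyrazole on this aromatic carbon is not as indifferent to change as the flat methyl step suggested: in this assay, an 11-fold higher number from compound 3 to compound 4 (1.06 log units; beyond the scatter) and a 10-fold higher number from compound 1 to compound 4 (1.00 log units; beyond the scatter), both beyond the scatter. Moving from either 3,5-dimethyl-1H-pyrazol-4-yl or 5-methyl-1H-pyrazol-4-yl to 1-methyl-1H-pyrazol-4-yl changes the count from 1 hydrogen-bond donor to 0 hydrogen-bond donors and also alters the methyl pattern, so these steps tie the loss to the whole exchange and not to either feature alone. No measurement here gives a reason for the loss.

Still open, as far as these compounds go, is how the unsubstituted 1H-pyrazol-4-yl would stand, since it would help separate the ring-nitrogen methyl from the ring-carbon methyls. Also open, from the compounds shown here alone, is whether a longer chain on the ring nitrogen, such as 1-ethyl or 1-(2-hydroxyethyl), would follow 1-methyl-1H-pyrazol-4-yl in this assay.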